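Amide-substituent variation on the shared core, compound 3

This account rests on a few compounds, and the source may have more. Where it says the series, first, only, none or still open, it means among the compounds named here.

The series keeps one core and varies the group on the carbonyl carbon of the anilide. Compound 1 `O=C(O)c1ccc2noc(-c3ccc(NC(=O)C4CCCC4)cc3)c2c1` carries a cyclopentyl there; in an assay for inhibition of inositol hexakisphosphate kinase 3 (Homo sapiens), read by colorimetric assay, coupled enzyme assay and malachite green, with a stated time of 120 min, in the presence of a further agent that is not named here (on this read-out lower numbers stand for stronger inhibition and higher numbers for weaker inhibition), compound 1 gives 240 nM. Compound 2 `O=C(O)c1ccc2noc(-c3ccc(NC(=O)c4ccccc4)cc3)c2c1` carries a phenyl; in this assay compound 2 gives 200 nM. The step of a 1.2-fold lower number from compound 1 to compound 2 (0.08 log units; within the scatter) is the only one measured, and it is within the scatter. Compound 2 therefore has the lower of the two numbers, but the gap to compound 1 does not separate them.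

Compound 3 `O=C(O)c1ccc2noc(-c3ccc(NC(=O)c4ccncn4)cc3)c2c1` is not yet measured. It differs from compound 2 by pyrimidin-4-yl in place of phenyl on a carbonyl carbon. Among the compounds with values here, the one measured step that bears on this position, a 1.2-fold lower number from compound 1 to compound 2 (0.08 log units; within the scatter), shows that exchanging cyclopentyl for phenyl on the carbonyl carbon left the number within the scatter. Within the data shown here, no measured pair shows the effect of a heteroaromatic ring at this place, so the data give no direction for the change. The expectation is a step of a 1.3-fold higher number from compound 2 to compound 3 (0.10 log units; within the scatter) in this assay that stays within the scatter, because a 1.2-fold lower number from compound 1 to compound 2 (0.08 log units; within the scatter) was itself within it. For compound 3 the estimate in this assay is 250 nM, with a range from 90 nM to 700 nM.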

Compound 3, half-maximal inhibitory concentration: 430 nM
Compound 3: middle estimate off by 1.7-fold (0.24 log units), on the low side; the measured number falls inside the stated range.
By their numbers in this assay, from the lowest: compounds 2, 1 and 3 (each within the scatter of the next, the first and the last beyond it).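

In this assay, within the data shown here, the group on the carbonyl carbon now shows that it can move the number: pyrimidin-4-yl in place of phenyl gives a 2.2-fold higher number from compound 2 to compound 3 (0.33 log units; beyond the scatter), the first step to lie beyond the scatter, though it remains modest. Both rings count 6 heavy atoms, so this step comes from an exchange that keeps the ring size and brings in 2 ring nitrogens and 2 hydrogen-bond acceptors, whereas the earlier exchange of cyclopentyl for phenyl changed the ring itself and stayed within the scatter. The same pyrimidin-4-yl against cyclopentyl gives a 1.8-fold higher number from compound 1 to compound 3 (0.25 log units; within the scatter), so the result separates pyrimidin-4-yl from phenyl but not from cyclopentyl, and nothing available explains the step between the two aromatic rings.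

From the compounds shown here alone, it remains open whether one ring nitrogen, as in a pyridin-2-yl or pyridin-3-yl group, would give a step of this size or whether both nitrogens are needed, and whether a pyrimidin-5-yl group would read like pyrimidin-4-yl. Also open, going by these compounds, is how a phenyl ring carrying a fluorine, a methoxy group or an amine would compare with the unsubstituted phenyl of compound 2.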